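A few compounds are considered here, and "the series" means these few. Any claim that something is new, unique, unknown or untested is made for them only; others in the source may bear on it.

The study concerns two measured compounds and one that awaits measurement in an ADME assay on MT4 cells (Homo sapiens) for cytotoxicity, with a stated time of 5 days (on this read-out higher numbers stand for lower toxicity in this test and lower numbers for higher toxicity in this test), all built on the same core. Compound 1 is `CC(C)(C)C#Cc1cc(N(C(=O)[C@H]2CC[C@H](C)CC2)[C@H]2CC[C@](O)(CO[C@H]3CCOC3)CC2)c(C(=O)O)s1`. In this assay compound 1 reaches only a limit of the test, > 20000 nM. Compound 2 is `CC(C)N(C(=O)[C@H]1CC[C@@H]2C[C@@H]2CC1)c1cc(C#CC(C)(C)C)sc1C(=O)O`. In this assay compound 2 also reaches only a limit, > 20000 nM. Compound 2 thus stands at the edge of the numbers shown, alongside compound 1, as the evidence records: the limit of > 20000 nM in this assay, at which 2 of the 2 values shown sit. Going by the values given here, no pair of measured compounds that differ in one place exists, so no measured step is available to lean on. Compound 3, `CC(C)N(c1cc(C#CC(C)(C)C)sc1C(=O)O)C(=O)[C@H]1CC[C@H](CF)CC1`, is not yet measured. It differs from compound 2 in one place: a group of 8 heavy atoms (7 carbon, 1 fluorine; one six-membered non-aromatic ring of carbon only) in place of a group of 8 heavy atoms (8 carbon; one three-membered non-aromatic ring of carbon only, one seven-membered non-aromatic ring of carbon only), on a carbonyl carbon. With both measured compounds sitting at the limit and nothing to set the change apart, the expected step from compound 2 to compound 3 in this assay is none beyond the usual scatter, namely a number no higher from compound 2 to compound 3 (the limit leaves the size open). Compound 3 is therefore expected to sit again at the limit, estimated near 20000 nM, within a range of 10000 nM to 40000 nM.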

Compound 3, half-maximal cytotoxic concentration: > 20000 nM
Compound 3: only a limit was reported (the forecaster's own chance of this, stated with the estimate: 80%); the middle value lies on the limit itself.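

Compound 2 and compound 3 both stand at a limit of this assay and not at a number, so no step between them can be read: the limit of > 20000 nM in this assay, at which 3 of the 3 values shown sit.

The compounds shown leave open where the half-maximal cytotoxic concentration of each lies, and whether any group on the carbonyl carbon would give a readable number in this assay.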